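Thiocarbamate variation on the shared core: tert-butyl to 1-methylcyclopropyl

This account rests on a few compounds, and the source may have more. Where it says the series, first, only, none or still open, it means among the compounds named here.

The series keeps one core and varies the group attached to the carbonyl on the piperidine nitrogen. Compound 1 `Cc1nc(S(C)(=O)=O)ccc1Oc1ncnc(OC2CCN(C(=O)OC(C)(C)C#N)CC2)c1F` is the carbamate with the 1-cyano-1-methylethyl ester; in a functional assay on isolated protein for inhibition of Glucose-dependent insulinotropic receptor (Rattus norvegicus), read by HTRF and cAMP accumulation (a higher number here means a larger maximal response, a lower number a smaller maximal response), compound 1 gives 97%. Compound 2 `Cc1nc(S(C)(=O)=O)ccc1Oc1ncnc(OC2CCN(C(=O)O[C@H](C)C(F)(F)F)CC2)c1F` carries the 1-(trifluoromethyl)ethyl ester and in this assay compound 2 gives 85%, with a number 12 percentage points lower from compound 1 to compound 2 (beyond the scatter). Compound 3 `Cc1nc(S(C)(=O)=O)ccc1Oc1ncnc(OC2CCN(C(=O)SC(C)(C)C)CC2)c1F` is the thiocarbamate with (tert-butyl)sulfanyl on the carbonyl carbon; in this assay compound 3 gives 76%. Compound 3 holds the lowest of the three numbers: a number 21 percentage points lower from compound 1 to compound 3 (beyond the scatter), while a number 9 percentage points lower from compound 2 to compound 3 (within the scatter).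

Compound 4 `Cc1nc(S(C)(=O)=O)ccc1Oc1ncnc(OC2CCN(C(=O)SC3(C)CC3)CC2)c1F` changes the sulfur substituent: 1-methylcyclopropyl in place of tert-butyl on a sulfur. Going by the values given here, none of the measured steps alters the group on the sulfur itself; the closest precedent is the ester-to-thioester swap of a number 9 percentage points lower from compound 2 to compound 3 (within the scatter), which stayed within the scatter, and the larger a number 21 percentage points lower from compound 1 to compound 3 (beyond the scatter). A four-carbon group is exchanged for another four-carbon group at the same place, so no step beyond the scatter is expected in this assay for compound 4, perhaps a slight drift either way, a number 1 percentage points higher from compound 3 to compound 4 (within the scatter). Compound 4 is therefore estimated at 77%, within a range from 64% to 91%.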

Compound 4, largest response reached (reported as efficacy), in percent of the reference or control that the assay uses: 77%
Beside the measured number, compound 4's estimate shows no gap at the digits printed; the range from low to high includes it.
By their numbers in this assay, from the lowest: compounds 3, 4 and 2 (each within the scatter of the next); then compound 1.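

On a sulfur whose other neighbour is the carbonyl carbon, 1-methylcyclopropyl in place of tert-butyl brings a three-membered ring into the group, yet in this assay the result is a number 1 percentage points higher from compound 3 to compound 4 (within the scatter) and the position tolerates this exchange as far as these two compounds go. With a second thiocarbamate in hand, the earlier relation of compound 3 to the two carbamates no longer rests on one sulfur substituent: a number 8 percentage points lower from compound 2 to compound 4 (within the scatter) and a number 20 percentage points lower from compound 1 to compound 4 (beyond the scatter) repeat that relation, with both thiocarbamates within the scatter of compound 2 and beyond it from compound 1. No available evidence bears on the origin of these differences.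

Still open, going by these compounds, is what a tert-butoxy or 1-methylcyclopropoxy group on the carbonyl carbon would give, since only such a pair would separate the sulfur from the group it carries. Also open, on these data alone, is how the response would stand with a cyclohexyl or phenyl group on the sulfur, or with an amine nitrogen on the carbonyl carbon in place of the sulfur.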